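Swapping the aryl group on compound 2: what to expect

This account rests on a few compounds, and the source may have more. Where it says the series, first, only, none or still open, it means among the compounds named here.

Compound 1 `CN(C)CCn1c(=O)c(=Cc2ccc(O)cc2)s/c1=C1\C(=O)Nc2ccc(F)cc21` gives 4200 nM in a functional assay on MDA-MB-231 cells (Homo sapiens) for inhibition, read by MTT assay, with a stated time of 72 h; a higher number here means a weaker inhibitor, a lower number a stronger inhibitor.
Compound 2 `CN(C)CCn1c(=O)c(=Cc2ccc(F)cc2F)s/c1=C1\C(=O)Nc2cc(F)ccc21` gives 8440 nM in this assay.
Compound 3 `CCN(CC)CCCn1c(=O)c(=Cc2ccc(F)cc2F)s/c1=C1\C(=O)Nc2cc(F)ccc21` gives 2100 nM in this assay.

Among these three, compound 2 has the highest number. Compound 1 sits nearest to it, and the gap between the two is within the scatter of this kind of measurement, so no order between them can be claimed. Compound 3 lies furthest away: a 4.0-fold lower number from compound 2 to compound 3 (0.60 log units; beyond the scatter). Going by the values given here, that one step is the only measured comparison of two compounds differing in a single place, and it concerns the amine at the end of the chain, not the aryl group.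

The unmeasured compound 4 `COc1ccc(OC)c(C=c2s/c(=C3\C(=O)Nc4cc(F)ccc43)n(CCN(C)C)c2=O)c1` differs from compound 2 at a different site: 2,5-dimethoxyphenyl in place of 2,4-difluorophenyl on a double-bonded chain carbon bound to an aromatic carbon. Among the compounds with values here, no measured pair shows the effect of changing the group on that double-bonded chain carbon while all else stays fixed. Compound 1 and compound 2 carry different aryl groups but also differ elsewhere, and their two values lie within the scatter anyway. There is thus no basis for predicting a shift beyond the scatter. Compound 4 is expected to come out near compound 2, with a 1.1-fold lower number from compound 2 to compound 4 (0.02 log units; within the scatter) reflecting essentially no change; the estimate is 8000 nM, within 2500 nM to 25000 nM.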

Compound 4, half-maximal inhibitory concentration: 14500 nM
Compound 4: middle estimate off by 1.8-fold (0.26 log units), on the low side; measured number inside the range.
By their numbers in this assay, from the lowest: compounds 3, 1, 2 and 4 (each within the scatter of the next, the first and the last beyond it).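

Going by these compounds alone, this is the first measured pair in which only the aryl group on the double-bonded chain carbon bound to an aromatic carbon changes, with the rest of the molecule held fixed, and it reads a 1.7-fold higher number from compound 2 to compound 4 (0.24 log units; within the scatter) in this assay. The change is a clear one in structure: 2,4-difluorophenyl, with 8 heavy atoms and 0 hydrogen-bond acceptors, gives way to 2,5-dimethoxyphenyl, with 10 heavy atoms and 2 hydrogen-bond acceptors, yet the two compounds cannot be told apart in this measurement. Nothing available gives a reason for this result.

A single pair describes only these two groups, so it sets no general rule for the position, and a phenyl ring carrying a carboxylic acid or an amine, or a pyridine ring in place of the phenyl, could read quite differently. Also open, going by these compounds, is whether 2,5-dimethoxyphenyl would read the same way on the diethylamino chain of compound 3, which is where the amine change gave a 4.0-fold lower number from compound 2 to compound 3 (0.60 log units; beyond the scatter).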